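Propyl for phenyl on a second chlorinated core

The source may report more compounds than this note shows. Statements on the series, on what has been measured and on what is new or still open speak of the compounds shown alone.

Measured compounds:
Compound 1 `CCCC1Oc2ccc(Cl)cc2N(O)C1=O` gives 156000 nM in an ADME assay on the whole organism for inhibition, with Oryza sativa as the target, with a stated time of 7 days; a lower number here means a stronger inhibitor, a higher number a weaker inhibitor.
Compound 2 `O=C1C(c2ccccc2)Oc2ccc(Cl)cc2N1O` gives 992000 nM in this assay.
Compound 3 `O=C1C(c2ccccc2)Oc2c(Cl)cccc2N1O` gives 384000 nM in this assay.

Compounds 1 and 2 share one core and differ only in the group on the saturated ring carbon; their step, (propyl in place of phenyl on a saturated ring carbon), gave a 6.4-fold lower number from compound 2 to compound 1 (0.80 log units; beyond the scatter). Compound 3 is built on a different core: it has the same atoms as compound 2 joined differently, and the difference between the two cores is not broken down here. Compound 4 `CCCC1Oc2c(Cl)cccc2N(O)C1=O` relates to compound 3 as compound 1 relates to compound 2, through (propyl in place of phenyl on a saturated ring carbon), a change made twice among these compounds, and with the place described in the same words in both cases, so it is the same change rather than a merely similar one.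

On that basis compound 4 is expected to come out at 70000 nM in this assay, with an estimated range from 25000 nM to 200000 nM. The step this estimate means, a 5.5-fold lower number from compound 3 to compound 4 (0.74 log units; beyond the scatter), is expected to resemble the measured one because a 6.4-fold lower number from compound 2 to compound 1 (0.80 log units; beyond the scatter) was the outcome of the same change on the other core, though the cores differ and a smaller step is allowed for.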

Compound 4, half-maximal inhibitory concentration: 614000 nM
Compound 4: middle estimate off by 8.8-fold (0.94 log units), on the low side; the whole stated range lies below it.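

On the second core, propyl in place of phenyl on a saturated ring carbon gave, in this assay, a 1.6-fold higher number from compound 3 to compound 4 (0.20 log units; within the scatter), so these two compounds cannot be told apart in this read-out. Set beside the earlier step, the same change did not carry over from one core to the other, and the two outcomes differ by more than the scatter of two such steps: the same change on two cores in this assay, a 6.4-fold lower number (0.80 log units; beyond the scatter) from compound 2 to compound 1 and a 1.6-fold higher number (0.20 log units; within the scatter) from compound 3 to compound 4, 10-fold (1.01 log units) apart, beyond the scatter of two such steps. This shows that the step seen on the core of compound 1 cannot simply be transferred to the core of compound 3, but it does not show what in the two cores is responsible, and two pairs say nothing about any further core.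

The compounds shown leave open whether a longer chain, such as pentyl, on the same saturated ring carbon would follow the result on one core or the other. They also leave open whether an amine or a carboxylic acid at that carbon would separate the two cores in the same way.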